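A few compounds are considered here, and "the series" means these few. Any claim that something is new, unique, unknown or untested is made for them only; others in the source may bear on it.

Compound 2 `C#CCCOC(=O)c1ccc(C(CC)(CC)c2ccc(OCCC(O)(CC)CC)c(C)c2)n1CC` is, in an assay on cells for agonist activity at vitamin D3 receptor (Homo sapiens), with a stated time of 96 h (a higher number here means that more compound is needed for the effect, a lower number that less compound is needed), the compound with the highest of the two numbers in this small set: compound 2 gives 6030 nM. Compound 1 `C=CCN(C)C(=O)c1ccc(C(CC)(CC)c2ccc(OCCC(O)(CC)CC)c(C)c2)n1CC` gives only a limit in this assay, > 10000 nM, and that is the limit noted at the limit of > 10000 nM in this assay, at which 1 of the 3 values shown sits. Compound 3 `CCOC(=O)C(CC(=O)OC)NC(=O)c1ccc(C(CC)(CC)c2ccc(OCCC(O)(CC)CC)c(C)c2)n1CC` gives 21 nM in this assay, and the step from compound 2 to compound 3 is a 290-fold lower number from compound 2 to compound 3 (2.46 log units; beyond the scatter). Compound 4 `CCn1c(C(=O)NC(CC(=O)O)C(=O)OC)ccc1C(CC)(CC)c1ccc(OCCC(O)(CC)CC)c(C)c1` has not yet been measured. It differs from compound 2 by a group of 10 heavy atoms (5 carbon, 1 nitrogen, 4 oxygen; no ring) in place of a group of 5 heavy atoms (4 carbon, 1 oxygen; no ring), on a carbonyl carbon. Among the compounds with values here, the measured step that bears most on this is the one a 290-fold lower number from compound 2 to compound 3 (2.46 log units; beyond the scatter), since the group entering compound 4 resembles the group that enters compound 3; the step of an at least 470-fold lower number from compound 1 to compound 3 (2.67 log units; beyond the scatter) points the same way, whereas the step of an at least 1.6-fold lower number from compound 1 to compound 2 (0.21 log units; that floor lies within the scatter) is small. A large fall in this assay is therefore expected for compound 4, of about a 150-fold lower number from compound 2 to compound 4 (2.18 log units; beyond the scatter). Compound 4 is estimated at 40 nM in this assay, within a range from 8 nM to 250 nM.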

Compound 4, half-maximal effective concentration: 26 nM
For compound 4 the middle estimate is 1.5-fold (0.19 log units) above the measured one; the range from low to high includes it.
By their numbers in this assay, from the lowest: compounds 3 and 4 (each within the scatter of the next); then compound 2. At a limit, above all of these: compound 1.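

At this carbonyl carbon, the large fall seen with compound 3 is not confined to that one group: this assay gives a 230-fold lower number from compound 2 to compound 4 (2.37 log units; beyond the scatter), and also an at least 380-fold lower number from compound 1 to compound 4 (2.58 log units; beyond the scatter). Compound 1 stands at a limit of the assay, so that last step is only a floor: the limit of > 10000 nM in this assay, at which 1 of the 4 values shown sits. The two groups that differ on the amide-type nitrogen cannot be told apart here, with a 1.2-fold higher number from compound 3 to compound 4 (0.09 log units; within the scatter).

The compounds shown leave open which part of the entering group goes with the fall. A simple amide carrying only a longer chain, an amine on that chain, or a carboxylic acid in place of each ester would bear on this.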